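The source may report more compounds than this note shows. Statements on the series, on what has been measured and on what is new or still open speak of the compounds shown alone.

Measured so far in a physicochemical assay for lipophilicity, at pH 7.4; a higher number here means a more lipophilic compound, a lower number a more polar compound:

Compound 1 `Cc1cc(C(=O)Nc2c(F)cccc2F)nn1Cc1cc(Cl)ccc1OCc1ccccc1` gives 3.7.
Compound 2 `Cc1cc(NC(=O)C(C)C)nn1Cc1cc(Cl)ccc1OCc1ccccc1` gives > 3.7, which is a limit of the assay rather than a number.
Compound 3 `Cc1cc(NC(=O)C2CCCC2)nn1Cc1cc(Cl)ccc1OCc1ccccc1` gives 3.5.

Of the two numbers shown, compound 1 carries the higher one, but the gap to its nearest neighbour is a number 0.20 log units lower from compound 1 to compound 3 (within the scatter), so the two cannot be told apart. Compound 2 sits at a limit (the limit of > 3.7 in this assay, at which 1 of the 3 values shown sits), so its distance from compound 1 is a number no lower from compound 1 to compound 2 (the limit leaves the size open).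

Compound 4 `Cc1cc(NC(=O)c2c(F)cccc2F)nn1Cc1cc(Cl)ccc1OCc1ccccc1` differs from compound 1 in one place: ((2,6-difluorophenyl)carbonyl)amino in place of (2,6-difluorophenyl)carbamoyl on an aromatic carbon. The two hold the same atoms, joined differently. Among the measured compounds shown here, no measured step reverses an amide in this way; the closest evidence is a number 0.20 log units lower from compound 1 to compound 3 (within the scatter), where the (2,6-difluorophenyl)carbamoyl gave way to a different acylamino group without a change beyond the scatter. He therefore expects no step beyond the scatter in this assay, and his estimate is no change at the digits printed from compound 1 to compound 4 (within the scatter). For compound 4 he estimates 3.7, between 3.3 and 4.1.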

Compound 4, distribution coefficient: > 3.7
Compound 4 ended at the assay's limit; the forecaster's own chance of this, stated with the estimate: 35%; the middle value sits exactly at the limit.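

In this assay compound 4 gives > 3.7, which is a limit of the assay and not a number. Among the compounds shown here, at this aromatic carbon, next to the ring nitrogen, ((2,6-difluorophenyl)carbonyl)amino in place of (2,6-difluorophenyl)carbamoyl, the same atoms joined differently, gives a number no lower from compound 1 to compound 4 (the limit leaves the size open), the first direct reading of reversing this amide, while 2,6-difluorophenyl in place of cyclopentyl on the carbonyl carbon gives a number at least 0.20 log units higher from compound 3 to compound 4 (that floor lies within the scatter). The step between compound 2 and compound 4 cannot be read, and both compounds sit at the limit: the limit of > 3.7 in this assay, at which 2 of the 4 values shown sit.

From the compounds shown here alone, how far compound 4 actually lies from compound 1 remains open, as does any ranking of the acylamino groups at this position. Also open, going by these compounds, is whether a carboxylic acid or a morpholine on the carbonyl carbon would give a number rather than a limit in this assay.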